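The compounds below may be only part of what the source reports. "The series", "measured", "known", "first", "only" and "open" are said of these compounds alone.

The measured compounds in an ADME assay on MDCKII-LE cells (Canis lupus familiaris) for permeability, read by transwell migration, in the apical to basolateral direction; a lower number here means that the compound crosses the layer more slowly, a higher number that the compound crosses the layer faster:

Compound 1, `CC1(C)CO[C@H]1CN([C@H](CCC(F)(F)F)C(N)=O)S(=O)(=O)c1ccc(Cl)cc1`: 26.4 10^-6 cm/s
Compound 2, `NC(=O)[C@@H](CCC(F)(F)F)N(C[C@@H]1CCCOC1)S(=O)(=O)c1ccc(Cl)cc1`: 18.4 10^-6 cm/s
Compound 3, `NC(=O)[C@@H](CCC(F)(F)F)N(CC1CCOCC1)S(=O)(=O)c1ccc(Cl)cc1`: 26.3 10^-6 cm/s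

Compound 1 gives the highest of the three numbers in this assay, but its lead is not one that can be read as an order: the step of a 1.0-fold lower number from compound 1 to compound 3 (0.00 log units; within the scatter) and the step of a 1.4-fold lower number from compound 1 to compound 2 (0.16 log units; within the scatter) both stay within the scatter, as does the step of a 1.4-fold higher number from compound 2 to compound 3 (0.16 log units; within the scatter). The three saturated oxygen rings on the chain carbon bound to the sulfonamide nitrogen therefore give numbers that cannot be told apart.

Compound 4, `NC(=O)[C@@H](CCC(F)(F)F)N(C[C@@H]1CCOC1)S(=O)(=O)c1ccc(Cl)cc1`, has not yet been measured in this assay. It differs from compound 1 in one place: oxolan-3-yl in place of 3,3-dimethyloxetan-2-yl on a saturated chain carbon bound to a sulfonamide nitrogen. The three measured steps all exchange one such ring for another at the same place, and none of them moves the number beyond the scatter. On that basis the step from compound 1 to compound 4 is expected to be small as well, a 1.1-fold lower number from compound 1 to compound 4 (0.04 log units; within the scatter), with no direction claimed. Compound 4 is accordingly estimated at 24 10^-6 cm/s in this assay, within a range from 14 10^-6 cm/s to 38 10^-6 cm/s.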

Compound 4, apparent permeability: 20.5 10^-6 cm/s
Compound 4: the middle estimate sits 1.2-fold (0.07 log units) above what was measured, and the stated range covers the measured number.
By their numbers in this assay, from the lowest: compounds 2, 4, 3 and 1 (each within the scatter of the next).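

In this assay compound 4 brings a five-membered ring to the saturated chain carbon bound to a sulfonamide nitrogen, and the exchange reads a 1.3-fold lower number from compound 1 to compound 4 (0.11 log units; within the scatter) and a 1.3-fold lower number from compound 3 to compound 4 (0.11 log units; within the scatter) and also a 1.1-fold higher number from compound 2 to compound 4 (0.05 log units; within the scatter) in turn. Four-, five- and six-membered oxygen rings at this place, with or without the two methyl groups of 3,3-dimethyloxetan-2-yl, thus give four numbers that cannot be told apart. Nothing measured here accounts for this lack of separation.

The compounds shown carry only saturated oxygen rings at this place, so it remains open whether an amine such as piperidine, a carboxylic acid or a plain alkyl chain would also stay within the scatter. On these data alone, whether changes elsewhere on the shared core would move the number is also open.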